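The compounds below may be only part of what the source reports. "The series", "measured", "known", "first", "only" and "open" are said of these compounds alone.

Of the compounds shown here, three that share a core have been tested in a functional assay on ECa-109 cells for inhibition, with ECa-109 cell line (Homo sapiens) as the target, read by MTT assay, with a stated time of 48 h; a higher number here means a weaker inhibitor, a lower number a stronger inhibitor. Among the measured compounds shown here, compound 3, `COc1cccc(Nc2nnc(Cl)c(Nc3cc(OC)c(OC)c(OC)c3)n2)c1`, gives 15900 nM, the lowest of the actual numbers so far. Compound 2, `CCOC(=O)c1ccc(Nc2nnc(Cl)c(Nc3cc(OC)c(OC)c(OC)c3)n2)cc1`, gives 46600 nM, and its gap to compound 3 lies beyond the usual scatter of repeated measurements. Compound 1, `COc1cc(Nc2nnc(Cl)c(Nc3cc(OC)c(OC)c(OC)c3)n2)cc(OC)c1OC`, gives > 50000 nM, which is a limit of the assay and not a number.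

The next compound is compound 4, `COc1cc(Nc2nc(Nc3ccccc3)nnc2Cl)cc(OC)c1OC`. It differs from compound 3 in one place, with hydrogen in place of methoxy on an aromatic carbon, meta to a large group: hydrogen in place of methoxy on an aromatic carbon. For the measured compounds named here, no measured pair of compounds shows this change on its own, so the expectation is only a rough one. A small move toward a higher number, meaning a somewhat weaker inhibitor, seems most likely, and a step within the scatter would be no surprise. The expected step is a 1.4-fold higher number from compound 3 to compound 4 (0.14 log units; within the scatter). For compound 4 the estimated value is 22000 nM, with an expected range from 8000 nM to 50000 nM.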

Compound 4, half-maximal inhibitory concentration: 12600 nM
For compound 4 the middle estimate is 1.7-fold (0.24 log units) above the measured one, within the range that was stated.
By their numbers in this assay, from the lowest: compounds 4 and 3 (each within the scatter of the next); then compound 2. At a limit, above all of these: compound 1.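

In this assay, putting hydrogen in place of methoxy on this aromatic carbon gives a 1.3-fold lower number from compound 3 to compound 4 (0.10 log units; within the scatter) so this methoxy group is not needed for the inhibition seen with compound 3. Hydrogen in place of ethoxycarbonyl on an aromatic carbon gives a 3.7-fold lower number from compound 2 to compound 4 (0.57 log units; beyond the scatter) and this shows that a single change on this ring can move the number by more than the usual variation between repeated measurements. Nothing measured here explains either step.

As far as these compounds go, it remains open whether an amine, a carboxylic acid or a longer chain such as propoxy on this ring would give a clearly lower number than the unsubstituted phenyl of compound 4. From the compounds shown here alone, it is also open whether a small atom such as fluorine or chlorine at this position would behave like hydrogen or like methoxy.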